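Compound 3 Estimated from Compounds 1 and 2

This account rests on a few compounds, and the source may have more. Where it says the series, first, only, none or still open, it means among the compounds named here.

Compound 1 `O=C(/C(=C/C1CCCCC1)CCl)c1ccccc1` gives 23000 nM in a functional assay on SW1573 cells (Homo sapiens) for inhibition, read by sulforhodamine B assay, with a stated time of 48 h; a lower number here means a stronger inhibitor of growth, a higher number a weaker inhibitor of growth. Compound 2 `CC(=O)OC/C(=C\C1CCCCC1)C(=O)c1ccccc1` gives 19000 nM in this assay, the lowest of the two numbers, although the step of a 1.2-fold lower number from compound 1 to compound 2 (0.08 log units; within the scatter) lies within the scatter. Compound 3 `CC(=O)OC/C(=C\c1ccccc1Br)C(=O)c1ccccc1` differs from compound 2 by 2-bromophenyl in place of cyclohexyl on a double-bonded chain carbon bound to a double-bonded chain carbon. For the measured compounds named here, no measured step touches this place; the only measured step, a 1.2-fold lower number from compound 1 to compound 2 (0.08 log units; within the scatter), concerns a different position and stayed within the scatter, so it gives no direction. Compound 3 is therefore expected to show a 1.3-fold lower number from compound 2 to compound 3 (0.10 log units; within the scatter), a change not clearly beyond the scatter. The estimate for compound 3 in this assay is 15000 nM, between 5000 nM and 45000 nM.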

Compound 3, concentration for 50% growth inhibition: 14000 nM
For compound 3 the middle estimate is 1.1-fold (0.03 log units) above the measured one, within the range that was stated.
By their numbers in this assay, from the lowest: compounds 3, 2 and 1 (each within the scatter of the next).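

For the compounds shown here, the step of a 1.4-fold lower number from compound 2 to compound 3 (0.13 log units; within the scatter) in this assay is the first reading at this place, on a double-bonded chain carbon bound to a double-bonded chain carbon. It shows that 2-bromophenyl can take the place of cyclohexyl there with no change beyond the scatter, so this exchange gives no direction for the position. No evidence is available that would explain this result. The compounds shown leave open whether an amine or a carboxylic acid at this place would move the number beyond the scatter. They also leave open how plain phenyl would compare with 2-bromophenyl.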